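Hydroxy to methyl on the aryl ring of compound 2

The source may hold more compounds than are shown below. What is called first, only, known or untested is meant among the compounds shown, and "the series" means these compounds.

Measured so far:
compound 1 `Cc1cccc(N(C)C(=O)c2ccc(Oc3ccccc3C)cc2)c1`: 55%
compound 2 `O=S(=O)(c1cccc(O)c1)N1CCN(c2cccc(O)c2)CC1`: 25%

In an assay on microsomes from placenta for inhibition of 17-beta-hydroxysteroid dehydrogenase type 2 (Homo sapiens), read by HPLC, with a stated time of 20 min, tested at 1 uM (on this read-out higher numbers stand for more inhibition at the one concentration tested (going by the name of the read-out) and lower numbers for less inhibition), compound 1 gives 55%. Compound 2 stands lowest of the two numbers, giving 25% in this assay, a value that lies beyond the scatter below that of compound 1. For the measured compounds named here, the two compounds share no single-point step, so their values are taken only as they stand.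

The next compound, compound 3 `Cc1cccc(N2CCN(S(=O)(=O)c3cccc(O)c3)CC2)c1`, keeps the core of compound 2 and differs in one place: methyl in place of hydroxy on an aromatic carbon. The 3-hydroxyphenyl of compound 2 becomes the 3-methylphenyl that is also present in compound 1.

Going by the values given here, no step of this kind has been measured in this assay. A modest rise is expected for compound 3, since compound 1, which also carries a 3-methylphenyl, gives 55%, though its remaining structure differs throughout. The step is estimated at a number 13 percentage points higher from compound 2 to compound 3 (beyond the scatter), an upward change, but one whose size is uncertain and could stay within the scatter. Compound 3 is estimated at 38% in this assay, with a range of 12% to 62%.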

Compound 3, a percentage reported as inhibition, at one concentration (the size of the read-out at that concentration, not a potency): 27%
Estimate against measurement, compound 3: 11 percentage points above; the measured number falls inside the stated range.
By their numbers in this assay, from the lowest: compounds 2 and 3 (each within the scatter of the next); then compound 1.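

In this assay the exchange of hydroxy for methyl on this aromatic carbon, meta to a large group, comes out as a number 2 percentage points higher from compound 2 to compound 3 (within the scatter), so the 3-hydroxyphenyl and the 3-methylphenyl are not told apart by this read-out at the one concentration tested. The hydrogen-bond donor and acceptor counted for hydroxy are absent from methyl, yet in this pair the inhibition shows no change beyond the scatter, a finding that rests on this single pair and sets no rule for other positions or other cores. Nothing available bears on why the step is so small.

Still open, as far as these compounds go, is whether another group at this position, such as an amine, a carboxylic acid or a longer alkyl chain, would move the inhibition beyond the scatter in this assay. Equally open, from the compounds shown here alone, is what the other hydroxy, kept in both compound 2 and compound 3, contributes to the inhibition of this shared core.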